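A few compounds are considered here, and "the series" means these few. Any claim that something is new, unique, unknown or untested is made for them only; others in the source may bear on it.

Measured so far in a functional assay on ECa-109 cells (Homo sapiens) for antiproliferative activity, with a stated time of 72 h; on this read-out lower numbers stand for stronger inhibition and higher numbers for weaker inhibition:
- compound 1 `COC(=O)CN(C)Cc1c(OC)cc(OC)c(C(=O)/C=C/c2ccccc2Cl)c1O`: 13900 nM
- compound 2 `COc1cc(OC)c(C(=O)/C=C/c2ccccc2Cl)c(O)c1CN(C)CC(=O)O`: 44400 nM
- compound 3 `CCN(C)Cc1c(OC)cc(OC)c(C(=O)/C=C/c2ccccc2Cl)c1O`: 1400 nM

Compound 3 has the lowest number of the three, and its steps to both others lie beyond the scatter, so it is the most potent of this small set. The next compound, compound 4 `CCN(CC)Cc1c(OC)cc(OC)c(C(=O)/C=C/c2ccccc2Cl)c1O`, keeps the shared core and alters only the amine side chain: methyl in place of hydrogen on a saturated chain carbon bound to an amine nitrogen. In words, a methyl stands in place of a hydrogen on a saturated chain carbon bound to an amine nitrogen, turning ethyl(methyl)amino into diethylamino.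

Going by the values given here, two measured steps touch that same kind of carbon: a 9.9-fold lower number from compound 1 to compound 3 (1.00 log units; beyond the scatter), and a 32-fold lower number from compound 2 to compound 3 (1.50 log units; beyond the scatter). Both are sizeable, so changes there can register in this assay. However, each of them exchanges methoxycarbonyl or carboxy for methyl, which is a much bigger swap than the one made here. Among the compounds with values here, no measured step adds just a methyl at this place, so they offer only a loose guide, and the direction stays open. The expectation is therefore no change beyond the scatter, anchored on compound 3 at 1400 nM. The expected step is a 1.1-fold higher number from compound 3 to compound 4 (0.06 log units; within the scatter). For compound 4 the estimated value is 1600 nM, with an expected range from 600 nM to 4500 nM.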

Compound 4, half-maximal inhibitory concentration: 7100 nM
Estimate against measurement, compound 4: 4.4-fold (0.65 log units) below; the whole stated range lies below it.
By their numbers in this assay, from the lowest: compound 3; then compounds 4 and 1 (each within the scatter of the next); then compound 2.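

In this assay, adding one methyl to turn ethyl(methyl)amino into diethylamino gives a 5.1-fold higher number from compound 3 to compound 4 (0.71 log units; beyond the scatter), so this saturated chain carbon bound to an amine nitrogen responds to a single extra carbon and not only to the much larger swaps seen earlier. Replacing the whole amine shows a split: (carboxymethyl)(methyl)amino to diethylamino gives a 6.3-fold lower number from compound 2 to compound 4 (0.80 log units; beyond the scatter), whereas ((methoxycarbonyl)methyl)(methyl)amino to diethylamino gives a 2.0-fold lower number from compound 1 to compound 4 (0.29 log units; within the scatter), so compound 1 and compound 4 cannot be told apart in this measurement, even though their amine groups differ considerably. Nothing available gives a reason for the sensitivity to one added methyl.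

Only one small step of this kind is shown, so it remains open whether the trend carries on to a longer chain, as in dipropylamino, or runs the other way to dimethylamino, which has one carbon fewer than the ethyl(methyl)amino of compound 3. As far as these compounds go, it is also open whether the same added methyl would have a similar effect in a compound with a different group in place of the chlorine on the shared core.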